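A new phenyl group on compound 2

This account rests on a few compounds, and the source may have more. Where it says the series, first, only, none or still open, it means among the compounds named here.

In a functional assay on HL-60 cells (Homo sapiens) for inhibition, read by MTT assay, with a stated time of 72 h (on this read-out lower numbers stand for stronger inhibition and higher numbers for weaker inhibition), compound 1 `Cc1nc(-c2cccc(F)c2)c(C(=O)N2CCN(c3cc(Cl)cc(Cl)c3)CC2)o1` gives 41.7 nM and compound 2 `COc1cc(OC)cc(N2CCN(C(=O)c3oc(C)nc3-c3cccc(F)c3)CC2)c1` gives 28.2 nM so the two stand within the scatter of each other. Compound 3 `Cc1ccc(C)c(N2CCN(C(=O)c3oc(C)nc3-c3cccc(F)c3)CC2)c1` carries 2,5-dimethylphenyl in place of 3,5-dimethoxyphenyl on an amine nitrogen in a ring. For the measured compounds named here, the only measured step is a 1.5-fold lower number from compound 1 to compound 2 (0.17 log units; within the scatter) for 3,5-dimethoxyphenyl in place of 3,5-dichlorophenyl, so no shift beyond the scatter is expected in this assay and no direction can be argued. The estimated step is a 1.3-fold higher number from compound 2 to compound 3 (0.13 log units; within the scatter) and stays within that scatter. Compound 3 is estimated at 38 nM with an expected range of 12 nM to 120 nM in this read-out.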

Compound 3, half-maximal inhibitory concentration: 204 nM
Compound 3: the middle estimate sits 5.4-fold (0.73 log units) below what was measured, outside the stated range (above it).
By their numbers in this assay, from the lowest: compounds 2 and 1 (each within the scatter of the next); then compound 3.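

In this assay, the group on this ring nitrogen now proves to matter: the change gives a 7.2-fold higher number from compound 2 to compound 3 (0.86 log units; beyond the scatter) and a 4.9-fold higher number from compound 1 to compound 3 (0.69 log units; beyond the scatter), whereas exchanging 3,5-dichlorophenyl for 3,5-dimethoxyphenyl had moved nothing beyond the scatter. Of the three groups shown, 2,5-dimethylphenyl alone stands apart from the other two. No measurement at hand accounts for the gap. The compounds shown leave open whether the weaker reading goes with the methyl groups themselves or with where they sit on the ring. Going by these compounds, how a plain phenyl group would read at this place also stays open.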